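The compounds below may be only part of what the source reports. "The series", "measured", "known", "first", "only" and "open" are said of these compounds alone.

Measured compounds:
compound 1, `CC(C)c1cccc(OC(=O)c2cn(-c3ccccc3)nc2-c2ccncc2)c1`, in a functional assay on MCF7 cells (Homo sapiens) for cytotoxicity, read by MTT assay, with a stated time of 48 h (on this read-out higher numbers stand for weaker inhibition and lower numbers for stronger inhibition), gives "nd(insoluble)" (no result reported)
compound 2, `Cc1ccc(C(C)C)c(OC(=O)c2cn(-c3ccccc3)nc2-c2ccncc2)c1`, in this assay gives > 100000 nM

Compound 1 carries no result in this assay and contributes no number to the series. The entry for compound 2 is a limit of this assay and not a measured concentration. Compound 2 therefore stands at the ceiling of the read-out (the limit of > 100000 nM in this assay, at which 1 of the 2 values shown sits), and its position relative to compound 1 cannot be stated. Within the data shown here, with two entries, neither of them a single number, no step between measured compounds exists, and no pattern can be drawn from what is measured.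

Compound 3, `O=C(O)c1cn(-c2ccccc2)nc1-c1ccncc1`, differs from compound 2 in one place: hydrogen in place of 2-isopropyl-5-methylphenyl on an oxygen next to a carbonyl group. Among the measured compounds shown here, no measured step covers this change. Because compound 2 sits at the limit (> 100000 nM), the expectation for compound 3 is no shift beyond the scatter in either direction, with a further limit the most likely outcome. The expected step is a step that the limit leaves unreadable from compound 2 to compound 3. For compound 3 the estimate is 150000 nM, with a range of 50000 nM to 500000 nM.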

Compound 3, half-maximal inhibitory concentration: > 100000 nM
Compound 3 ended at the assay's limit (the forecaster's own chance of this, stated with the estimate: 85%); the middle value does not contradict the limit.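

No new step can be read between compound 2 and compound 3, because both entries are limits and not measured concentrations: the limit of > 100000 nM in this assay, at which 2 of the 3 values shown sit.

The compounds shown leave open whether any member of the series gives a single number in this assay, and so what hydrogen in place of 2-isopropyl-5-methylphenyl does to the read-out.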